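The source may hold more compounds than are shown below. What is called first, only, known or untested is meant among the compounds shown, and "the series" means these compounds.

In a functional assay on the whole organism for inhibition, with Rattus norvegicus as the target, read by paw edema, with stated times of 30 min and 5 h, at a dose of 0.28 mmol/kg by the oral route (a higher number here means more inhibition at the dose given (going by the name of the read-out), a lower number less inhibition), the measured compounds stand as follows:
Compound 1 `NC(=O)c1nc(-c2ccccc2)n(-c2ccc(S(N)(=O)=O)cc2)n1` gives 42%.
Compound 2 `NS(=O)(=O)c1ccc(-n2nc(C(=O)NC3CCCCC3)nc2-c2ccccc2)cc1` gives 42%.
Compound 3 `NNC(=O)c1nc(-c2ccccc2)n(-c2ccc(S(N)(=O)=O)cc2)n1` gives 32%.

All three share one core and differ only in what sits on the amide-type nitrogen of the carboxamide. Compound 3 has the lowest of the three numbers, but its gaps to the others are small: the step of a number 10 percentage points lower from compound 1 to compound 3 (within the scatter) and the step of a number 10 percentage points lower from compound 2 to compound 3 (within the scatter) both lie within the scatter, so no order among the three can be claimed. Likewise no change at the digits printed from compound 1 to compound 2 (within the scatter) shows that cyclohexyl in place of hydrogen on that nitrogen changed nothing that can be read.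

Compound 4 `COC(=O)c1nc(-c2ccccc2)n(-c2ccc(S(N)(=O)=O)cc2)n1` has not yet been measured. It differs from compound 3 in one place: methoxy in place of aminoamino on a carbonyl carbon. Among the compounds with values here, this change goes one step further than the measured ones, since the amide-type nitrogen itself is replaced rather than decorated, so none of the measured steps covers it exactly. The closest guidance is that every change tried so far at this end of the molecule stayed within the scatter in this assay. For compound 4 the expected step is therefore a number 6 percentage points higher from compound 3 to compound 4 (within the scatter), with no change beyond the scatter. Compound 4 is thus estimated at 38%, in a range from 22% to 54%.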

Compound 4, a percentage reported as inhibition, in the whole organism at one dose (the size of the read-out at that dose, not a potency): 46%
The estimate for compound 4 lay 8 percentage points below the measured number, and the stated range covers the measured number.
By their numbers in this assay, from the lowest: compounds 3, 1, 2 and 4 (each within the scatter of the next, the first and the last beyond it).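

In this assay, within the data shown here, methoxy in place of aminoamino on the carbonyl carbon gives a number 14 percentage points higher from compound 3 to compound 4 (beyond the scatter) and this is the first step at this position to lie beyond the scatter, although it is only modest. Compared with the other two nitrogen-bearing groups, the same methoxy gives a number 4 percentage points higher from compound 2 to compound 4 (within the scatter) and a number 4 percentage points higher from compound 1 to compound 4 (within the scatter) and both steps lie within the scatter, so the methoxycarbonyl group can be told apart only from aminocarbamoyl and not from the plain or cyclohexyl-bearing carboxamide. This also shows that the amide-type nitrogen can be removed altogether without losing the inhibition seen at this dose, as the methoxy group has 0 hydrogen-bond donors where aminoamino has 2, so a nitrogen on this carbonyl carbon is not required for that inhibition to appear.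

No measurement at hand gives a reason for the step from the aminoamino group to the methoxy group. As far as these compounds go, it remains open how a carboxylic acid at this carbonyl carbon, or an ethoxy group or a longer chain in place of methoxy, would read in this assay.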